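This account rests on a few compounds, and the source may have more. Where it says the series, first, only, none or still open, it means among the compounds named here.

Measured compounds:
compound 1 `COc1ccccc1Oc1ccc2c(NCCCNCc3ccco3)ccnc2c1`: 6500 nM
compound 2 `COc1cccc(CNCCCNc2ccnc3cc(Oc4ccc(Cl)cc4)ccc23)c1O`: 5700 nM
compound 3 `COc1ccc(F)cc1CNCCCNc1ccnc2cc(CCC(C)C)ccc12`: 890 nM

In an ADME assay on HepG2 cells (Homo sapiens) for cytotoxicity, read by luminescence, CellTiter-Glo and ATP content, with a stated time of 72 h (a higher number here means that more compound is needed for the effect, a lower number that less compound is needed), compound 2 gives 5700 nM, the second highest of the three numbers. Compound 1 gives 6500 nM, within the scatter of compound 2. Compound 3 gives 890 nM, a lower number beyond the scatter. Compound 4 `COc1cccc(CNCCCNc2ccnc3cc(Cc4ccccc4)ccc23)c1O` is not yet measured. It differs from compound 2 in one place: benzyl in place of 4-chlorophenoxy on an aromatic carbon. Going by the values given here, no step between measured compounds shares this change, so only the spread across the three measured compounds guides the expectation. A moderate step toward a lower number is expected in this assay, a 1.9-fold lower number from compound 2 to compound 4 (0.28 log units; within the scatter), since compound 3 gives 890 nM. Compound 4 is expected to give about 3000 nM, with a range from 1200 nM to 8000 nM.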

Compound 4, half-maximal effective concentration: 5720 nM
Compound 4: middle estimate off by 1.9-fold (0.28 log units), on the low side, within the range that was stated.
By their numbers in this assay, from the lowest: compound 3; then compounds 2, 4 and 1 (each within the scatter of the next).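

In this assay the change of 4-chlorophenoxy to benzyl on this aromatic carbon gives a 1.0-fold higher number from compound 2 to compound 4 (0.00 log units; within the scatter). Going by these compounds alone, this is the first direct reading at this position: in this pair, the loss of the chlorine and the hydrogen-bond acceptor that leave with 4-chlorophenoxy does not shift the number beyond the scatter. No measurement at hand accounts for this flat step.

Open, going by these compounds, is how an amine or a carboxylic acid on this aromatic carbon would read. Also open, on these data alone, is whether the same change gives a similar step elsewhere.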